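The source may hold more compounds than are shown below. What is called first, only, known or untested is meant among the compounds shown, and "the series" means these compounds.

Measured in a functional assay on A549 cells (Homo sapiens) for antiproliferative activity, read by MTT assay, with a stated time of 48 h; a higher number here means a weaker inhibitor, a lower number a stronger inhibitor:
- compound 1 `COC(=O)c1ccc(N2CC3(CCN(C(=O)c4cc(C)c5[nH]ncc5c4)CC3)CC2=O)cc1`: 2110 nM
- compound 2 `O=C(c1ccc2[nH]c(-c3ccccc3)nc2c1)N1CCC2(CC1)CC(=O)N(c1ccc(C(F)(F)F)cc1)C2`: 1920 nM

Among the compounds with values here, only two numbers are available so far. Compound 2 at 1920 nM and compound 1 at 2110 nM lie within the usual scatter of repeated measurements, so the data do not rank them. Both sit in the same range of this assay, and that range is the starting point here.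

Compound 3 `CC(C)c1ccc(-c2nc3cc(C(=O)N4CCC5(CC4)CC(=O)N(c4ccc(C(F)(F)F)cc4)C5)ccc3[nH]2)cc1` keeps everything in compound 2 except one spot: isopropyl in place of hydrogen on an aromatic carbon. In words, this is isopropyl in place of hydrogen on an aromatic carbon, para to a large group, so a phenyl becomes a 4-isopropylphenyl.

Within the data shown here, no measured pair differs in one place only, so nothing here shows directly what this change does. With no such guide, the estimate stays close to the value of compound 2 at 1920 nM and leans only slightly toward a lower number. No shift beyond the scatter is expected, and the range is kept wide. The expected change is a 1.5-fold lower number from compound 2 to compound 3 (0.17 log units; within the scatter) and it stays within the scatter. For compound 3 the estimated value is 1300 nM, with an expected range from 400 nM to 3800 nM.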

Compound 3, half-maximal inhibitory concentration: 1030 nM
Estimate against measurement, compound 3: 1.3-fold (0.10 log units) above, within the range that was stated.
By their numbers in this assay, from the lowest: compounds 3, 2 and 1 (each within the scatter of the next, the first and the last beyond it).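

Measured in this assay, replacing hydrogen with isopropyl on an aromatic carbon, para to a large group, turns phenyl into 4-isopropylphenyl and gives a 1.9-fold lower number from compound 2 to compound 3 (0.27 log units; within the scatter), so the data cannot tell these two compounds apart. Within the data shown here, this is the first direct look at this position, and it shows that a group of three carbon atoms can be placed there while the compound stays in the same range as its parent, with no step beyond the usual scatter in either direction. Nothing measured alongside this result explains why the outcome is what it is, and a single step within the scatter offers no firm trend to explain.

The compounds shown leave open whether an amine, a carboxylic acid or a longer chain at this same place would give a number that stands clearly apart from that of compound 2. They also leave open whether isopropyl on another carbon of this ring would give a similar result, or whether a clear step in either direction can be reached by changing this ring at all.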